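Sulfamoyl to methylsulfonyl on the shared core: cytotoxicity

The source may hold more compounds than are shown below. What is called first, only, known or untested is meant among the compounds shown, and "the series" means these compounds.

Compound 1 `NS(=O)(=O)c1ccc(NC(=O)CSc2nnc(N3C(=O)CSC3c3ccccc3)s2)cc1` is the reference point of this series. In an ADME assay on MT4 cells (Homo sapiens) for cytotoxicity, read by MTT assay, with a stated time of 5 days (a lower number here means that less compound is tolerated, a higher number that more compound is tolerated), compound 1 gives 99200 nM. Compound 3 `O=C1CSC(c2cccc(Cl)c2)N1c1nnc(S)s1`, which keeps only the thiazolidinone part of the shared core with a free thiol on the thiadiazole, gives 238000 nM in this assay. Among the two readable numbers compound 1 stands lowest, and the gap to compound 3 lies beyond the scatter. Compound 2 `NS(=O)(=O)c1ccc(NC(=O)CSc2nnc(N3C(=O)CSC3c3ccccc3Cl)s2)cc1` gives only a limit in this assay, >= 18800 nM. The step that the limit leaves unreadable from compound 1 to compound 2 cannot be sized because of the limit of >= 18800 nM in this assay, at which 1 of the 3 values shown sits.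

Compound 4 `CS(=O)(=O)c1ccc(NC(=O)CSc2nnc(N3C(=O)CSC3c3ccccc3)s2)cc1` differs from compound 1 by methyl in place of amino on a sulfonyl sulfur. Within the data shown here, no measured step touches the sulfonyl end of the molecule: the single step recorded, from compound 1 to compound 2, changes a different place and is unreadable, and compound 3 differs from compound 1 in several places at once. Nothing in the data therefore points to a step beyond the scatter in this assay for this change, in either direction. Compound 4 is expected to give 100000 nM, with a range from 40000 nM to 250000 nM. The expected step of a 1.0-fold higher number from compound 1 to compound 4 (0.00 log units; within the scatter) is accordingly estimated as none beyond the scatter.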

Compound 4, half-maximal cytotoxic concentration: 131000 nM
Compound 4: the middle estimate sits 1.3-fold (0.12 log units) below what was measured; measured number inside the range.
By their numbers in this assay, from the lowest: compounds 1, 4 and 3 (each within the scatter of the next, the first and the last beyond it).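

Among these compounds, the swap of amino for methyl on a sulfonyl sulfur gives a 1.3-fold higher number from compound 1 to compound 4 (0.12 log units; within the scatter) in this assay, which makes it the only step that can be read. The sulfonyl end of the shared core therefore takes this change, with the loss of the hydrogen-bond donor carried by the amino group, without a step beyond the scatter in this read-out; the sulfamoyl group is thus not shown to matter for the tolerated concentration in this comparison, and that holds for this one pair, on the unsubstituted phenyl of compound 1. The other step on this core, chloro in place of hydrogen on an aromatic carbon, cannot be read, so nothing can be said of how the change would behave alongside that chloro group, because the only value for that compound is a limit: the limit of >= 18800 nM in this assay, at which 1 of the 4 values shown sits.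

Still open, on these data alone, is whether larger groups on the same sulfonyl sulfur, such as a dimethylamino group, a morpholine or a longer chain like propyl, stay equally close to compound 1 in this assay. Also open, as far as these compounds go, is whether a carboxylic acid in place of the whole 4-sulfamoylphenyl substituent's sulfonyl group would do the same.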